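From Trifluoromethoxy to Dimethylamino in a Growth Inhibitor

The source may report more compounds than this note shows. Statements on the series, on what has been measured and on what is new or still open speak of the compounds shown alone.

In a functional assay on KB cells (Homo sapiens) for inhibition, read by sulforhodamine B assay (a higher number here means a weaker inhibitor of growth, a lower number a stronger inhibitor of growth), compound 3 (`Oc1cccc2[nH]c(-c3ccc(-c4ccc(-c5ccc(OC(F)(F)F)cc5)cc4)cc3)nc12`) gives 3310 nM. Compound 2 (`Oc1cccc2[nH]c(-c3ccc(-c4ccc(-c5ccc(C(F)(F)F)cc5)cc4)cc3)nc12`) gives 4320 nM, level with compound 3 within the scatter. Compound 1 (`CN(C)c1ccc(-c2ccc(-c3ccc(-c4nc5ccccc5[nH]4)cc3)cc2)cc1`), which lacks the hydroxy group, stands well higher at 39300 nM.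

Compound 4 (`CN(C)c1ccc(-c2ccc(-c3ccc(-c4nc5c(O)cccc5[nH]4)cc3)cc2)cc1`) keeps the core of compound 3 and changes one group: dimethylamino in place of trifluoromethoxy on an aromatic carbon, with dimethylamino in place of trifluoromethoxy on an aromatic carbon. Among the compounds with values here, the one measured step at this place, a 1.3-fold lower number from compound 2 to compound 3 (0.12 log units; within the scatter), stayed within the scatter, but it exchanged trifluoromethyl for trifluoromethoxy and says little about dimethylamino. Compound 1 carries dimethylamino, but on a different core, so the data do not isolate this group. A modest move toward weaker inhibition is therefore expected, and the estimated step is a 1.8-fold higher number from compound 3 to compound 4 (0.26 log units; within the scatter). Compound 4 is expected at about 6000 nM, with an estimated range of 1800 nM to 20000 nM.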

Compound 4, concentration for 50% growth inhibition: 4200 nM
Beside the measured number, compound 4's estimate is 1.4-fold (0.15 log units) above it; low and high end bracket the measured number.
By their numbers in this assay, from the lowest: compounds 3, 4 and 2 (each within the scatter of the next); then compound 1.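

In this assay the end group at this place made no readable difference: dimethylamino matched trifluoromethoxy (a 1.3-fold higher number from compound 3 to compound 4 (0.10 log units; within the scatter)) and trifluoromethyl (a 1.0-fold lower number from compound 2 to compound 4 (0.01 log units; within the scatter)). Within the data shown here, the hydroxy group, which no earlier pair isolated, carries the one step beyond the scatter (a 9.4-fold lower number from compound 1 to compound 4 (0.97 log units; beyond the scatter)). No measurement given here accounts for either result.

As far as these compounds go, it remains open whether a carboxylic acid or a primary amine on the same aromatic carbon would also leave the number unchanged. From the compounds shown here alone, it is equally open whether a methoxy group could stand in for the hydroxy on the shared core.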